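The compounds below may be only part of what the source reports. "The series", "measured", "known", "first", "only" and "open" are said of these compounds alone.

Two close analogues sharing one core have been examined in an assay on HEK293 cells for agonist activity at transient receptor potential cation channel subfamily M member 8 (Homo sapiens), read by fluorescence and calcium flux, with a stated time of 15 min; on this read-out lower numbers stand for an effect already at smaller amounts and higher numbers for an effect only at larger amounts of compound. Compound 1, `CCN(Cc1ccccn1)C(=O)COc1ccc(C)cc1`, gives 16000 nM in this assay, so an effect appears only at large amounts. Compound 2, `CCN(Cc1ccncc1)C(=O)COc1ccc(C)cc1`, is reported in this assay as "not active" (no number reported), which means no number was obtained and compound 2 stands at the weak end of what the assay can show. Compound 3, `CCN(Cc1c[nH]nn1)C(=O)COc1ccc(C)cc1`, has not yet been measured. The change from compound 2 to compound 3 is 1H-1,2,3-triazol-4-yl in place of pyridin-4-yl on a saturated chain carbon bound to an amide-type nitrogen. For the measured compounds named here, compound 2 gave no number in this assay; no step between measured compounds is known here, and the expectation for compound 3 rests only on compound 1 reading 16000 nM and compound 2 reading "not active" (no number reported). Compound 3 is expected to remain weak, with an estimated value of 30000 nM, most likely between 8000 nM and 100000 nM, and a real chance that again no number is reported.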

Compound 3, half-maximal effective concentration: 31100 nM
For compound 3 the middle estimate is 1.0-fold (0.02 log units) below the measured one; low and high end bracket the measured number.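

In this assay, swapping the pyridin-2-yl ring for the 1H-1,2,3-triazol-4-yl ring gives a 1.9-fold higher number from compound 1 to compound 3 (0.29 log units; within the scatter) and so does not separate these two rings, even though one is five-membered and the other six-membered. For the compounds shown here, compound 2 has no number, so the step from it to compound 3 cannot be read as a size; the printed results show only that compound 3 gives a number where compound 2, with pyridin-4-yl, does not. No measurement here explains why these rings behave as they do.

Still open, going by these compounds, is whether an aromatic ring is needed on this chain carbon at all, or whether a simple amine or a carboxylic acid would also give a number. On these data alone, it is also open whether pyridin-3-yl would read like pyridin-2-yl or like pyridin-4-yl.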